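Methoxycarbonyl in Place of Vinyl on Compound 3

The source may report more compounds than this note shows. Statements on the series, on what has been measured and on what is new or still open speak of the compounds shown alone.

In a functional assay on FM3A cells (Mus musculus) for cytotoxicity (on this read-out lower numbers stand for an effect already at smaller amounts and higher numbers for an effect only at larger amounts of compound), compound 1 `CCOC(C)OOC1(OOC)CCCCCCCCCCC1` gives 12000 nM, compound 2 `COOC1(OOCCCCCCO)CCCCCCCCCCC1` gives 1600 nM and compound 3 `C=CCCOOC1(OOC)CCCCCCCCCCC1` gives 6000 nM. Compound 3 thus lies within the scatter of compound 1, while its number is higher than that of compound 2. Compound 4 `COOC1(OOCCC(=O)OC)CCCCCCCCCCC1` has not yet been measured. It differs from compound 3 as follows: methoxycarbonyl in place of vinyl on a saturated chain carbon, two bonds along the chain from an oxygen on an unsaturated carbon. Put another way, but-3-en-1-yl gives way to 2-(methoxycarbonyl)ethyl.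

The closest measured change is a 3.8-fold higher number from compound 2 to compound 3 (0.57 log units; beyond the scatter), a modest step in which vinyl replaces 4-hydroxybutyl at the same place. Also relevant are a 7.5-fold lower number from compound 1 to compound 2 (0.88 log units; beyond the scatter), likewise modest, and a 2.0-fold lower number from compound 1 to compound 3 (0.30 log units; within the scatter), which stays within the scatter. None of these steps brings in a methoxycarbonyl group, so they fix neither size nor direction for this change. No shift beyond the scatter is therefore expected, and the estimated change is a 1.3-fold lower number from compound 3 to compound 4 (0.12 log units; within the scatter). Compound 4 is estimated at 4500 nM, with an expected range of 1500 nM to 13000 nM.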

Compound 4, half-maximal effective concentration: 1400 nM
Compound 4: middle estimate off by 3.2-fold (0.51 log units), on the high side, outside the stated range (below it).
By their numbers in this assay, from the lowest: compounds 4 and 2 (each within the scatter of the next); then compounds 3 and 1 (each within the scatter of the next).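

The new value shows that this position responds to a change that adds no hydrogen-bond donor: in this assay, methoxycarbonyl in place of vinyl gives a 4.3-fold lower number from compound 3 to compound 4 (0.63 log units; beyond the scatter). Methoxycarbonyl in place of 4-hydroxybutyl gives a 1.1-fold lower number from compound 2 to compound 4 (0.06 log units; within the scatter), so the ester-bearing chain and the hydroxyl-bearing chain cannot be told apart on this read-out. 2-(Methoxycarbonyl)ethyl in place of 1-ethoxyethyl on an oxygen gives an 8.6-fold lower number from compound 1 to compound 4 (0.93 log units; beyond the scatter), which runs in the same direction as the step to the 6-hydroxyhexyl compound. Nothing available explains these shifts.

Going by these compounds, what a carboxylic acid or a primary amide would give in place of methoxycarbonyl remains open. On these data alone, it is also open whether a longer chain carrying the same ester would stay within the scatter of compound 4.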